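The source may report more compounds than this note shows. Statements on the series, on what has been measured and on what is new or still open speak of the compounds shown alone.

For the measured compounds named here, compound 2 `Cc1ccc(NC(=O)CSc2snnc2-c2ccc(Br)cc2Br)cc1` is the only member of the series with a number in an ADME assay on MT4 cells (Homo sapiens) for cytotoxicity, read by MTT assay, with a stated time of 5 days; a lower number here means that less compound is tolerated, a higher number that more compound is tolerated: compound 2 gives 24000 nM. Compound 1 `Cc1cccc(C)c1NC(=O)CSc1snnc1-c1ccc(Br)cc1Br` reaches only the limit of this assay, >= 198000 nM (the limit of >= 198000 nM in this assay, at which 1 of the 2 values shown sits). Going by the values given here, the single measured step, an at least 8.2-fold lower number from compound 1 to compound 2 (0.91 log units; beyond the scatter), concerns a different change on the amide-type nitrogen than the one now followed. Compound 3 `O=C(CSc1snnc1-c1ccc(Br)cc1Br)Nc1ccccc1Br` differs from compound 2 by 2-bromophenyl in place of 4-methylphenyl on an amide-type nitrogen. Among the compounds with values here, no measured step shares this change, so no shift beyond the scatter is assumed in this assay. Compound 3 is expected at 30000 nM, between 8000 nM and 150000 nM. The expected step is a 1.3-fold higher number from compound 2 to compound 3 (0.10 log units; within the scatter).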

Compound 3, half-maximal cytotoxic concentration: > 221000 nM
Compound 3 gave a limit, no number (the forecaster's own chance of this, stated with the estimate: 25%); middle value at least 7.3-fold (0.86 log units) away from the limit.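

Putting 2-bromophenyl in place of 4-methylphenyl on the amide-type nitrogen gives an at least 9.2-fold higher number from compound 2 to compound 3 (0.96 log units; beyond the scatter) in this assay, so this change moves the read-out clearly. Compound 3 stands at a limit, not a number: the limit of > 221000 nM in this assay, at which 1 of the 3 values shown sits.

Among the compounds shown, 2,6-dimethylphenyl and 2-bromophenyl both end at limits and only 4-methylphenyl gives a number, so the high end is reached with two different groups.

The step between the two limits cannot be read. Open, from the compounds shown here alone, is how 4-bromophenyl, 2-methylphenyl or an aminophenyl group on this nitrogen would read.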